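Swapping a Chlorophenyl for a Thiophene Ring

A few compounds are considered here, and "the series" means these few. Any claim that something is new, unique, unknown or untested is made for them only; others in the source may bear on it.

The compounds here share one core, carrying an aryl group on a saturated ring carbon. Compound 2 `COc1ccc(-c2nsc3c2NC(=O)CC3c2cccc(Cl)c2)cc1` bears a 3-chlorophenyl group there and in a functional assay on MDA-MB-231 cells (Homo sapiens) for antiproliferative activity, read by CellTiter-Glo, with a stated time of 96 h (on this read-out lower numbers stand for stronger inhibition and higher numbers for weaker inhibition), compound 2 gives 1620 nM. Compound 1 `COc1ccc(-c2nsc3c2NC(=O)CC3c2ccc3c(c2)OCCO3)cc1` carries a benzodioxane-type group on the same carbon, and in this assay compound 1 gives 1710 nM; the two values sit within the scatter of each other, so neither can be called stronger. Compound 3 `COc1ccc(-c2nsc3c2NC(=O)CC3c2cccc(F)c2)cc1` has a fluoro in place of chloro on an aromatic carbon. In this assay compound 3 reaches only a limit of the assay, > 2000 nM, and the limit of > 2000 nM in this assay, at which 1 of the 3 values shown sits, shows that this is the limit at which one of the three values sits. The step of an at least 1.2-fold higher number from compound 2 to compound 3 (0.09 log units; that floor lies within the scatter) therefore points toward weaker inhibition, though its floor lies within the scatter.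

Compound 4 `COc1ccc(-c2nsc3c2NC(=O)CC3c2ccsc2)cc1` differs from compound 2 in one place: thiophen-3-yl in place of 3-chlorophenyl on a saturated ring carbon. Among the compounds with values here, no measured step covers exchanging a six-membered ring for a five-membered one, and the only step available, the halogen swap, moved the value to the limit. Weaker or unchanged inhibition is therefore expected, as a step of a 1.6-fold higher number from compound 2 to compound 4 (0.21 log units; within the scatter). Compound 4 is estimated at 2600 nM, with a range from 1100 nM to 6500 nM.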

Compound 4, half-maximal inhibitory concentration: 192 nM
Estimate against measurement, compound 4: 14-fold (1.13 log units) above; measured number below the stated range.
By their numbers in this assay, from the lowest: compound 4; then compounds 2 and 1 (each within the scatter of the next). At a limit, above all of these: compound 3.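

Within the data shown here, the saturated ring carbon turns out to respond strongly to the kind of ring it carries, which the earlier compounds did not reveal, since their aryl groups gave no values clearly apart from one another: in this assay, the change to thiophen-3-yl gives an 8.4-fold lower number from compound 2 to compound 4 (0.93 log units; beyond the scatter). Measured against the 3-fluorophenyl group, the same ring gives an at least 10-fold lower number from compound 3 to compound 4 (1.01 log units; beyond the scatter), so thiophen-3-yl stands clearly apart from both halogenated phenyl groups. The value for compound 3 is a limit of the assay and not a number: the limit of > 2000 nM in this assay, at which 1 of the 4 values shown sits.

This single change removes the chlorine, shrinks the six-membered ring to a five-membered one and brings in a sulfur, and the compounds shown cannot tell which of these accounts for the lower number. An unsubstituted phenyl, a furan-3-yl or a thiophen-2-yl group on the same carbon would help to separate these possibilities, showing whether the sulfur, the smaller ring or the loss of the halogen matters, and whether the placement of the sulfur in the ring counts.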